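The compounds below may be only part of what the source reports. "The series", "measured", "known", "first", "only" and "open" are said of these compounds alone.

Two imidazolylpropyl guanidines anchor this account. Compound 1 `N=C(NCCCc1c[nH]cn1)NCCC(c1ccccc1)c1ccccn1` and compound 2 `N=C(NCCCc1c[nH]cn1)NCCC(c1ccc(F)cc1)c1cccnc1` share that core and differ only in the two aromatic rings carried on the chain carbon. In a functional assay on muscle tissue for agonist activity at histamine H2 receptor (Cavia porcellus) (on this read-out lower numbers stand for smaller maximal responses and higher numbers for larger maximal responses), compound 1 gives 0.7, and in this assay compound 2 gives 0.8; the two numbers lie within the usual scatter of each other, so compound 2 stands alongside compound 1 rather than apart from it, and nothing can be said of an order between them.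

Compound 3 `N=C(NCCCc1c[nH]cn1)NCCC(c1ccccc1)c1ccc(F)cc1` is the next step from compound 2: phenyl in place of pyridin-3-yl on a saturated chain carbon bound to an aromatic carbon and a saturated chain carbon. Both measured compounds carry one pyridine ring and both reach a similar fraction of the reference response, so no step beyond the scatter is expected here; if anything, a slight shift downward is possible. The expected step from compound 2 to compound 3 is a number 0.10 lower from compound 2 to compound 3 (within the scatter). Compound 3 is therefore estimated at 0.7, with a range from 0.45 to 0.9.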

Compound 3, intrinsic activity: the largest response reached, as a fraction of the reference agonist's: 0.7
Compound 3: the middle estimate sits on the measured number at the digits printed; the range from low to high includes it.
By their numbers in this assay, from the lowest: compounds 1, 3 and 2 (each within the scatter of the next).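

In this assay, exchanging pyridin-3-yl for phenyl on a saturated chain carbon bound to an aromatic carbon and a saturated chain carbon gives a number 0.10 lower from compound 2 to compound 3 (within the scatter), so compound 3, which carries no pyridine ring, stands alongside the two compounds that carry one. Exchanging pyridin-2-yl for 4-fluorophenyl at this same place gives no change at the digits printed from compound 1 to compound 3 (within the scatter), and neither exchange of a pyridine ring for a carbon-only ring moves the read-out beyond the scatter. No supporting measurement bears on why these rings can be exchanged.

The compounds shown leave open how an amine, a carboxylic acid or a longer chain at this place would read in this assay. No pair shown differs only in the fluorine, so its part stays unread.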